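From 2-fluorophenyl to 4-chloro-3-(trifluoromethyl)phenyl: a small expected step

The compounds below may be only part of what the source reports. "The series", "measured", "known", "first", "only" and "open" are said of these compounds alone.

- compound 1 `O=C1Nc2ccccc2/C1=C/c1ccc(-c2cn(-c3ccccc3F)nn2)cc1` 10500 nM
- compound 2 `N#Cc1ccccc1-n1cc(-c2ccc(/C=C3\C(=O)Nc4ccccc43)cc2)nn1` 14400 nM
- compound 3 `O=C1Nc2ccc(F)cc2/C1=C/c1ccc(-c2cn(-c3ccccc3F)nn2)cc1` 8980 nM

In a functional assay on HT-29 cells (Homo sapiens) for inhibition, read by CCK-8 assay, with a stated time of 24 h (on this read-out lower numbers stand for stronger inhibition and higher numbers for weaker inhibition), compound 3 gives 8980 nM, a number that cannot be told apart from those of the other two compounds, since all three lie within the usual scatter of one another. Compound 4 `O=C1Nc2ccc(F)cc2/C1=C/c1ccc(-c2cn(-c3ccc(Cl)c(C(F)(F)F)c3)nn2)cc1` differs from compound 3 in one group: on an aromatic nitrogen of the five-membered aromatic ring with 3 nitrogen, 4-chloro-3-(trifluoromethyl)phenyl stands in place of 2-fluorophenyl (4-chloro-3-(trifluoromethyl)phenyl in place of 2-fluorophenyl on an aromatic nitrogen).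

Going by the values given here, two measured steps bear on this change. The closer one, cyano in place of fluoro on that same phenyl ring, is a 1.4-fold higher number from compound 1 to compound 2 (0.14 log units; within the scatter). The other, fluoro in place of hydrogen on an aromatic carbon of the shared core, is a 1.2-fold lower number from compound 1 to compound 3 (0.07 log units; within the scatter). Both stay within the scatter, but neither tests a chloro or trifluoromethyl group, so the data offer no firm direction in this assay. A small shift toward a lower number is expected, though this is a judgement and may not exceed the scatter. The expected change is a 1.6-fold lower number from compound 3 to compound 4 (0.21 log units; within the scatter). For compound 4 the estimated value is 5500 nM, with an expected range from 1800 nM to 14000 nM.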

Compound 4, half-maximal inhibitory concentration: 16500 nM
The estimate for compound 4 lay 3.0-fold (0.48 log units) below the measured number; the measured number lies above the stated range.
By their numbers in this assay, from the lowest: compounds 3, 1, 2 and 4 (each within the scatter of the next).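

In this assay the whole group on the aromatic nitrogen is exchanged, rather than one substituent on it, and the outcome is a 1.8-fold higher number from compound 3 to compound 4 (0.26 log units; within the scatter) and so cannot be told apart from no change. The earlier compounds shown here showed this only for cyano in place of fluoro on the same ring, whereas this result extends it to a much larger group: 4-chloro-3-(trifluoromethyl)phenyl has 11 heavy atoms against 7 in 2-fluorophenyl, yet all four compounds still form a chain in which each lies within the scatter of the next. No measurement in hand gives a reason for this result.

On these data alone, the chloro and trifluoromethyl groups enter together here and only on the fluorinated core of compound 3, so what each does alone, or what the pair does on the core of compound 1, stays open. As far as these compounds go, it also stays open whether an amine or a carboxylic acid on this phenyl ring, or a plain alkyl chain in place of the ring, would move the number beyond the scatter.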